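Replacing the 2-fluorophenyl group of compound 1

The compounds below may be only part of what the source reports. "The series", "measured", "known", "first", "only" and "open" are said of these compounds alone.

Compound 1 (`COC(=O)CC/C(C)=C/Cc1c(OC)c(C)c2c(c1OCC#CCN1CCN(c3ccccc3F)CC1)C(=O)OC2`) is tested in a functional assay on A549 cells (Homo sapiens) for inhibition, read by sulforhodamine B assay (on this read-out higher numbers stand for weaker inhibition and lower numbers for stronger inhibition), where compound 1 gives 45300 nM. Compound 2 (`COC(=O)CC/C(C)=C/Cc1c(OC)c(C)c2c(c1OCC#CCN1CCCc3ccccc31)C(=O)OC2`) gives 18000 nM in this assay. Compound 1 therefore holds the higher of the two numbers and is the weaker inhibitor of the pair, with a gap beyond the scatter.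

Compound 3 (`COC(=O)CC/C(C)=C/Cc1c(OC)c(C)c2c(c1OCC#CCN1CCN(C(=O)C3COc4ccccc4O3)CC1)C(=O)OC2`) departs from compound 1 at one place: (2,3-dihydro-1,4-benzodioxin-2-yl)carbonyl in place of 2-fluorophenyl on an amine nitrogen in a ring. The counted difference is (2,3-dihydro-1,4-benzodioxin-2-yl)carbonyl in place of 2-fluorophenyl on an amine nitrogen in a ring. Within the data shown here, no measured pair isolates a change at this place, so the series offers no direct precedent for it. Among the measured compounds shown here, the only numerical guide is the span of the two measured compounds, with compound 2 at 18000 nM marking the stronger end. In this assay, no step beyond the scatter is expected, and the expected change is a small one towards stronger inhibition, a 1.5-fold lower number from compound 1 to compound 3 (0.18 log units; within the scatter). For compound 3 the estimated value is 30000 nM, with an expected range of 12000 nM to 75000 nM.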

Compound 3, half-maximal inhibitory concentration: > 50000 nM
Compound 3 ended at the assay's limit; the forecaster's own chance of this, stated with the estimate: 15%; middle value at least 1.6-fold (0.22 log units) away from the limit.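

The reading for compound 3 in this assay is a limit and not a number: the limit of > 50000 nM in this assay, at which 1 of the 3 values shown sits.

Replacing 2-fluorophenyl with (2,3-dihydro-1,4-benzodioxin-2-yl)carbonyl on the amine nitrogen in a ring gives an at least 1.1-fold higher number from compound 1 to compound 3 (0.04 log units; that floor lies within the scatter), so this first measured change at the position fixes only a floor, and that floor lies within the scatter. The result still excludes a gain for this replacement, since compound 3 shows no stronger inhibition than compound 1, although the size of any loss cannot be read.

Open, going by these compounds, is whether the outcome follows from the carbonyl or from the 2,3-dihydro-1,4-benzodioxin part of the entering group; a benzoyl group on the same amine nitrogen would separate the two. Also open, on these data alone, is whether a simpler aryl group at this position, such as plain phenyl or pyridyl, would move the number in either direction, and whether any group on this nitrogen can give stronger inhibition than 2-fluorophenyl does.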